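Dimethylamino Replaces Difluoromethoxy in an Antiproliferative Series

The source may report more compounds than this note shows. Statements on the series, on what has been measured and on what is new or still open speak of the compounds shown alone.

Compound 3 `COc1ccc2nc(C)cc(NCc3ccc(OC(F)F)cc3)c2c1` was tested in a functional assay on MCF-10A cells (Homo sapiens) for antiproliferative activity, with a stated time of 48 h (a lower number here means that less compound is needed, a higher number that more compound is needed for the effect), where compound 3 gives 10400 nM. Among the three compounds measured, compound 3 stands second highest; its nearest neighbour is compound 2 `COc1ccc2nc(C)cc(NCc3ccc(C(C)(C)C)cc3)c2c1`, for which compound 2 gives 6900 nM, and the furthest is compound 1 `COc1ccc2nc(C)cc(NCc3ccc(C)cc3)c2c1`, where compound 1 gives 18800 nM. Both gaps lie within the scatter: a 1.5-fold higher number from compound 2 to compound 3 (0.18 log units; within the scatter) and a 1.8-fold lower number from compound 1 to compound 3 (0.26 log units; within the scatter). For the measured compounds named here, the only step beyond the scatter is a 2.7-fold lower number from compound 1 to compound 2 (0.44 log units; beyond the scatter), a modest one. Compound 4 `COc1ccc2nc(C)cc(NCc3ccc(N(C)C)cc3)c2c1` carries dimethylamino in place of difluoromethoxy on an aromatic carbon, a change on the aromatic carbon para to a large group. Going by the values given here, every exchange at that position so far has moved the number little; the step of a 1.0-fold lower number from compound 3 to compound 4 (0.02 log units; within the scatter) is expected to stay within the scatter. Compound 4 is therefore estimated at 10000 nM, between 4000 nM and 25000 nM.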

Compound 4, half-maximal effective concentration: 15100 nM
Beside the measured number, compound 4's estimate is 1.5-fold (0.18 log units) below it, within the range that was stated.
By their numbers in this assay, from the lowest: compounds 2, 3, 4 and 1 (each within the scatter of the next, the first and the last beyond it).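

In this assay, a group attached through nitrogen now sits at this position, and the exchange stays within the scatter against difluoromethoxy, a 1.5-fold higher number from compound 3 to compound 4 (0.16 log units; within the scatter), and against methyl, a 1.2-fold lower number from compound 1 to compound 4 (0.10 log units; within the scatter). Only the exchange with tert-butyl goes beyond it, a 2.2-fold higher number from compound 2 to compound 4 (0.34 log units; beyond the scatter), so compound 2 stands apart from compound 4 as it does from compound 1, though not from compound 3. No evidence is available to explain this result. On these data alone, whether a carboxylic acid, a primary amine or a longer chain at this position would stay in the same range remains open.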